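Working notes: a methyl on the 2-hydroxyethyl chain

A few compounds are considered here, and "the series" means these few. Any claim that something is new, unique, unknown or untested is made for them only; others in the source may bear on it.

Compound 1 `O=C(NCc1ccc(F)cc1)c1nc(NCCO)c2cccnc2c1O` gives 91000 nM
Compound 2 `C[C@H](Nc1c(C(=O)NCc2ccc(F)cc2)nc(Br)c2cccnc12)c1ccccc1` is recorded as "not determined" (no result reported)

For the measured compounds named here, in a toxicity assay on C8166 cells (Homo sapiens) for cytotoxicity, read by MTT assay, with a stated time of 72 h (a lower number here means that less compound is tolerated, a higher number that more compound is tolerated), compound 1 is the only compound with a number, so it has no rank. Compound 2 offers no comparison.

Compound 3 `C[C@@H](CO)Nc1nc(C(=O)NCc2ccc(F)cc2)c(O)c2ncccc12` has not yet been measured. Relative to compound 1 it shows methyl in place of hydrogen on a saturated chain carbon bound to a nitrogen on an aromatic ring and a saturated chain carbon and so 2-hydroxyethyl becomes 1-(hydroxymethyl)ethyl. Going by the values given here, the series contains no measured step, so the expectation rests on this single structural change and on compound 1 at 91000 nM alone. In this assay the expected 1.1-fold lower number from compound 1 to compound 3 (0.03 log units; within the scatter) stays within the usual scatter, with no clear direction. Compound 3 is estimated at 85000 nM (expected range 35000 nM to 200000 nM).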

Compound 3, half-maximal cytotoxic concentration: 107000 nM
Compound 3: the middle estimate sits 1.3-fold (0.10 log units) below what was measured; low and high end bracket the measured number.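

In this assay the methyl on a saturated chain carbon bound to a nitrogen on an aromatic ring gives a 1.2-fold higher number from compound 1 to compound 3 (0.07 log units; within the scatter) and so leaves 2-hydroxyethyl and 1-(hydroxymethyl)ethyl indistinguishable. Compound 1 alone could not show that this chain tolerates one added methyl with no difference beyond the scatter, and this now holds for that single change. No measurement at hand explains this result.

The compounds shown leave open whether this assay would also stay within the scatter with a longer chain on the same nitrogen, or with an amine or a carboxylic acid in place of the chain-end hydroxyl. They also leave open how the opposite configuration at the methyl-bearing carbon would read.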